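This account rests on a few compounds, and the source may have more. Where it says the series, first, only, none or still open, it means among the compounds named here.

In a functional assay on SW-620 cells (Homo sapiens) for cytotoxicity (a higher number here means a weaker inhibitor of growth, a lower number a stronger inhibitor of growth), compound 1 `COc1ccc(C2=C(c3ccc(SC)cc3)CC3CCCN3C2=O)cc1O` gives 20000 nM. Compound 2 `CSc1ccc(C2=C(c3ccc(O)cc3)C(=O)N3CCCC3C2)cc1` is reported only as a limit, > 100000 nM, so its place on the scale is bounded and not known as a number. Going by the values given here, the one measured step is an at least 5.0-fold higher number from compound 1 to compound 2 (0.69 log units; beyond the scatter), with 4-hydroxyphenyl in place of 3-hydroxy-4-methoxyphenyl on a double-bonded ring carbon. Compound 3 `CSc1ccc(C2=C(c3ccc(Br)cc3)C(=O)N3CCCC3C2)cc1` alters that same group of compound 2: bromo in place of hydroxy on an aromatic carbon, para to a large group, so that 4-hydroxyphenyl becomes 4-bromophenyl. Among the compounds with values here, no measured step makes this exact exchange, so the step to compound 2 is the only guide, and it shows that a change on this group can move the number beyond the scatter. A change of similar, modest size is therefore expected in this assay, and its direction can be seen only toward a lower number. The estimated change is an at least 2.5-fold lower number from compound 2 to compound 3 (0.39 log units; beyond the scatter). For compound 3 the expected value is 40000 nM, with an estimated range from 12000 nM to 100000 nM.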

Compound 3, concentration for 50% growth inhibition: 7000 nM
The estimate for compound 3 lay 5.7-fold (0.76 log units) above the measured number; the measured number lies below the stated range.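

In this assay, putting bromo in place of hydroxy on the aromatic carbon para to a large group gives an at least 14-fold lower number from compound 2 to compound 3 (1.15 log units; beyond the scatter), so one heavy atom at this place separates a compound without a measured number from one with a measured number. The 4-bromophenyl group also compares favourably with the 3-hydroxy-4-methoxyphenyl group, with a 2.9-fold lower number from compound 1 to compound 3 (0.46 log units; beyond the scatter), which shows that a hydroxy on this phenyl group is not required for growth inhibition in this series. Compound 2 is a limit and not a number, which leaves the step into compound 3 with a lower bound on its size and no fixed value: the limit of > 100000 nM in this assay, at which 1 of the 3 values shown sits.

The compounds shown leave open whether this result is particular to bromo or would also be seen with another group at the same place, such as chloro, methyl or an amine. They also leave open whether the methoxy of compound 1 adds anything when bromo is present, as a 3-bromo-4-methoxyphenyl group would show.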